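The compounds below may be only part of what the source reports. "The series", "measured", "known", "first", "only" and "open" are said of these compounds alone.

Compound 1 `C/C(=C\c1cc(-c2ccccc2)cs1)C(N)=O` carries the shared core with an unsubstituted six-membered aromatic ring of carbon only. In an ADME assay on NIH3T3 cells (Mus musculus) for cytotoxicity, read by CCK-8 assay, with a stated time of 24 h (a lower number here means a stronger inhibitor, a higher number a weaker inhibitor), compound 1 gives > 50000 nM, which is a limit of the assay rather than a number. Compound 2 `C/C(=C\c1cc(-c2ccc(C)cc2)cs1)C(N)=O` has a methyl in place of hydrogen on an aromatic carbon of that ring. In this assay compound 2 gives > 50000 nM, again a limit. Compound 3 `C/C(=C\c1cc(-c2ccc(C#N)cc2)cs1)C(N)=O` has a cyano in place of hydrogen there. In this assay compound 3 gives > 50000 nM, also a limit. Compound 3 therefore stands exactly where the other two measured compounds stand, since all three values sit at the same limit (the limit of > 50000 nM in this assay, at which 3 of the 3 values shown sit). The steps a step that the two limits leave unreadable from compound 1 to compound 2, a step that the two limits leave unreadable from compound 1 to compound 3 and a step that the two limits leave unreadable from compound 2 to compound 3 are all unreadable, each joining two limits. Compound 4 `C/C(=C\c1cc(-c2ccc(S(C)(=O)=O)cc2)cs1)C(N)=O` differs from compound 3 by methylsulfonyl in place of cyano on an aromatic carbon. Among the compounds with values here, no measured step bears on this change in a readable way; the only guide is that every measured compound, whatever group sits on the ring, sat at the limit (the limit of > 50000 nM in this assay, at which 3 of the 3 values shown sit). Compound 4 is therefore expected to show no step beyond the scatter, a step that the limit leaves unreadable from compound 3 to compound 4, and most probably to report only a limit once more. The estimate for compound 4 in this assay is 60000 nM, with a range from 30000 nM to 150000 nM.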

Compound 4, half-maximal inhibitory concentration: > 50000 nM
Compound 4 was reported as a limit; the forecaster's own chance of this, stated with the estimate: 85%; the middle value is on the limit's open side.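

In this assay compound 4 gives > 50000 nM, which is a limit. No step to compound 4 from compound 1, compound 2 or compound 3 can be read, each joining two limits: the limit of > 50000 nM in this assay, at which 4 of the 4 values shown sit.

The compounds shown leave open whether these four differ at all in cytotoxicity, and at what concentration any of them would reach half-maximal inhibition.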